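Amide variation on the hexafluoro-carbinol naphthylamide series

The source may hold more compounds than are shown below. What is called first, only, known or untested is meant among the compounds shown, and "the series" means these compounds.

In a functional assay (Sus scrofa) with sulfonylurea receptors; K-ATP channels (Homo sapiens) as the target (a lower number here means that less compound is needed, a higher number that more compound is needed for the effect), compound 3 `O=C(Nc1c(C(O)(C(F)(F)F)C(F)(F)F)ccc2ccccc12)C1CCC1` gives 81.3 nM, the lowest of the three numbers: compound 2 `CC(C)=CC(=O)Nc1c(C(O)(C(F)(F)F)C(F)(F)F)ccc2ccccc12` gives 550 nM and compound 1 `CCCC(=O)Nc1c(C(O)(C(F)(F)F)C(F)(F)F)ccc2ccccc12` gives 708 nM, so that an 8.7-fold lower number from compound 1 to compound 3 (0.94 log units; beyond the scatter) and a 6.8-fold lower number from compound 2 to compound 3 (0.83 log units; beyond the scatter), while a 1.3-fold lower number from compound 1 to compound 2 (0.11 log units; within the scatter). Compound 4 `O=C(Nc1c(C(O)(C(F)(F)F)C(F)(F)F)ccc2ccccc12)c1cccc([N+](=O)[O-])c1` differs from compound 3 by 3-nitrophenyl in place of cyclobutyl on a carbonyl carbon. Among the measured compounds shown here, the measured steps bear only loosely on this change: both show that the cyclobutyl of compound 3 gave a modestly lower number than either open chain, but no measured compound carries an aromatic ring on the carbonyl carbon, so the size of the present step is open. With the cyclobutyl leaving, compound 4 is expected to come out higher with wide uncertainty, a 3.1-fold higher number from compound 3 to compound 4 (0.49 log units; beyond the scatter). In this assay compound 4 is estimated at 250 nM, between 60 nM and 1000 nM.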

Compound 4, half-maximal effective concentration: 427 nM
Beside the measured number, compound 4's estimate is 1.7-fold (0.23 log units) below it; the measured number falls inside the stated range.
By their numbers in this assay, from the lowest: compound 3; then compounds 4, 2 and 1 (each within the scatter of the next).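

In this assay, an aromatic ring on the carbonyl carbon does not keep the lower number of the cyclobutyl, with a 5.3-fold higher number from compound 3 to compound 4 (0.72 log units; beyond the scatter). Set against the open chains, 3-nitrophenyl stays within the scatter, with a 1.3-fold lower number from compound 2 to compound 4 (0.11 log units; within the scatter) and a 1.7-fold lower number from compound 1 to compound 4 (0.22 log units; within the scatter), so among these four compounds only the cyclobutyl of compound 3 stands apart. No measurement at hand accounts for this. Still open, as far as these compounds go, is whether cyclopropyl or cyclohexyl on the carbonyl carbon would match cyclobutyl, and whether a plain phenyl would read differently from 3-nitrophenyl.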